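A few compounds are considered here, and "the series" means these few. Any claim that something is new, unique, unknown or untested is made for them only; others in the source may bear on it.

Working notes on the series, read in a functional assay on MCF7 cells (Homo sapiens) for cytotoxicity, read by MTT assay, with a stated time of 72 h; a lower number here means a stronger inhibitor, a higher number a weaker inhibitor. Compound 1 `O=C1C(=Cc2ccc(O)cc2)C(=O)N(c2ccc(Cl)cc2)N1c1ccc(Cl)cc1` gives 23200 nM, compound 2 `COc1cc(C=C2C(=O)N(c3ccc(Cl)cc3)N(c3ccc(Cl)cc3)C2=O)ccc1O` gives 22800 nM, and compound 3 `COc1ccccc1C=C1C(=O)N(c2ccc(Cl)cc2)N(c2ccc(Cl)cc2)C1=O` gives 26300 nM. Compound 3 cannot be separated from the other two: a 1.1-fold higher number from compound 1 to compound 3 (0.05 log units; within the scatter), and a 1.2-fold higher number from compound 2 to compound 3 (0.06 log units; within the scatter).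

Compound 4 `O=C1C(=Cc2ccccc2)C(=O)N(c2ccc(Cl)cc2)N1c1ccc(Cl)cc1` differs from compound 3 by hydrogen in place of methoxy on an aromatic carbon, ortho to a large group, which reads as 2-methoxyphenyl to phenyl: hydrogen in place of methoxy on an aromatic carbon.

The closest measured change is a 1.0-fold lower number from compound 1 to compound 2 (0.01 log units; within the scatter), a methoxy for hydrogen exchange, the reverse kind of change, though not at the same place. The two steps to compound 3 also rearrange the substituents on this ring, and neither leaves the scatter. Among the compounds with values here, no measured compound has a plain phenyl there, so the range stays wide. On these steps, an estimated 1.1-fold lower number from compound 3 to compound 4 (0.02 log units; within the scatter) is expected, with no shift beyond the scatter in either direction. The expected value for compound 4 is 25000 nM, with an estimated range of 13000 nM to 48000 nM.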

Compound 4, half-maximal inhibitory concentration: 20200 nM
Beside the measured number, compound 4's estimate is 1.2-fold (0.09 log units) above it; the measured number falls inside the stated range.
By their numbers in this assay, from the lowest: compounds 4, 2, 1 and 3 (each within the scatter of the next).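

With a plain phenyl now in the series, compound 4 cannot be separated from the substituted compounds in this assay: a 1.3-fold lower number from compound 3 to compound 4 (0.11 log units; within the scatter) for hydrogen in place of methoxy, a 1.1-fold lower number from compound 1 to compound 4 (0.06 log units; within the scatter) for hydrogen in place of hydroxy, and a 1.1-fold lower number from compound 2 to compound 4 (0.05 log units; within the scatter) for phenyl in place of 4-hydroxy-3-methoxyphenyl. Neither the hydroxy nor the methoxy is therefore needed to hold the number at this level, as compound 4 carries neither group. The methoxy exchange can now be read twice, at different places on this ring, and the two readings agree: the same change on two cores in this assay, a 1.0-fold lower number (0.01 log units; within the scatter) from compound 1 to compound 2 and a 1.3-fold higher number (0.11 log units; within the scatter) from compound 4 to compound 3, 1.3-fold (0.12 log units) apart, within the scatter of two such steps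

From the compounds shown here alone, all four compounds carry only hydrogen, hydroxy or methoxy on this ring, so the effect of an amine or a carboxylic acid there remains open. The rest of the shared core stays constant, so these compounds say nothing about its contribution.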